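A few compounds are considered here, and "the series" means these few. Any claim that something is new, unique, unknown or untested is made for them only; others in the source may bear on it.

Measured compounds:
compound 1 `COc1ccc(/C=C/C2CC=CC(=O)N2)cc1OC`: > 964 uM
compound 2 `COc1cc(/C=C/C2CC=CC(=O)N2)cc(OC)c1`: 203 uM

For the measured compounds named here, in a functional assay on NCI/ADR cells (Homo sapiens) for inhibition, read by sulforhodamine B assay, with a stated time of 48 h (on this read-out lower numbers stand for stronger inhibition of growth and higher numbers for weaker inhibition of growth), compound 2 gives 203 uM, and this is the only number in the set. Compound 1 reaches only a limit of this assay, > 964 uM. Where compound 2 stands is thus described by one value alone, with the second entry being a limit, as the evidence notes: the limit of > 964 uM in this assay, at which 1 of the 2 values shown sits. Compound 3 `COc1cc(/C=C/C2CC=CC(=O)N2)cc(OC)c1OC` has not yet been measured in this assay. It differs from compound 2 in a single place: methoxy in place of hydrogen on an aromatic carbon. Going by the values given here, since no step between measured compounds is known, the size of this change can only be expected. The writer expects a modest move toward stronger inhibition of growth in this assay, and the estimate for compound 3 is 100 uM, ranging from 30 uM to 400 uM. This estimate means an expected step of a 2.0-fold lower number from compound 2 to compound 3 (0.31 log units; beyond the scatter).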

Compound 3, concentration for growth inhibition (reported as GI): > 864 uM
Compound 3: a limit, no number (the forecaster's own chance of this, stated with the estimate: 20%); middle value at least 8.6-fold (0.93 log units) from the limit.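

In this assay, methoxy in place of hydrogen on an aromatic carbon, ortho to two methoxy groups and para to a group of 9 heavy atoms, gives an at least 4.2-fold higher number from compound 2 to compound 3 (0.62 log units; beyond the scatter). For the compounds shown here, this is the first readable step in the set, and it runs toward weaker inhibition of growth, so at this position the added methoxy does not strengthen the inhibition seen with compound 2. The entry for compound 3 is a limit and not a number: the limit of > 864 uM in this assay, at which 1 of the 3 values shown sits.

Going by these compounds, the step between compound 1 and compound 3 cannot be read, as both entries are limits: the limit of > 964 uM in this assay, at which 1 of the 3 values shown sits. Whether a hydroxyl group or an amine on this same aromatic carbon would give a lower number than methoxy does remains open.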